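A few compounds are considered here, and "the series" means these few. Any claim that something is new, unique, unknown or untested is made for them only; others in the source may bear on it.

Measured in a functional assay on HCT-116 cells (Homo sapiens) for antiproliferative activity; on this read-out higher numbers stand for weaker inhibition and lower numbers for stronger inhibition:
- compound 1 `COc1cc(/C=C\Cc2cc(O)c3ccsc3c2)cc(OC)c1OC`: 84 nM
- compound 2 `COc1cc(/C=C\Cc2cc(O)c3ccoc3c2)cc(OC)c1OC`: 54 nM

Only these two values are available so far. Compound 1 and compound 2 lie within the usual scatter of each other, so no order can be drawn between them.

The next compound is compound 3 `COc1cc(/C=C\Cc2cc(OP(=O)(O)O)c3ccsc3c2)cc(OC)c1OC`. It keeps the core of compound 1 and has one change, on an oxygen on an aromatic ring: a group of 4 heavy atoms (3 oxygen, 1 phosphorus; no ring) in place of a hydrogen atom, on an oxygen on an aromatic ring. Within the data shown here, no measured pair carries this change, so the expectation rests only on compound 1 at 84 nM and on the structural change itself. In this assay, a small move towards a higher number is expected, staying within the scatter. The expected change is a 1.5-fold higher number from compound 1 to compound 3 (0.19 log units; within the scatter). Compound 3 is estimated at 130 nM, with an expected range from 40 nM to 420 nM.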

Compound 3, half-maximal inhibitory concentration: 3000 nM
Compound 3: the middle estimate sits 23-fold (1.36 log units) below what was measured; the measured number lies above the stated range.
By their numbers in this assay, from the lowest: compounds 2 and 1 (each within the scatter of the next); then compound 3.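

In this assay, the oxygen on the aromatic ring proves sensitive to substitution: a group of 4 heavy atoms (3 oxygen, 1 phosphorus; no ring) in place of its hydrogen atom gives a 36-fold higher number from compound 1 to compound 3 (1.55 log units; beyond the scatter) and sets compound 3 clearly apart from the other two. Compound 1 and compound 2 both carry the hydrogen atom on this oxygen, so they gave no reading of this position, only values within the scatter of each other. Nothing available on this series accounts for the size of the step.

Open, going by these compounds, is whether the loss belongs to this particular group or to any replacement of the hydrogen atom, which a methyl or acetyl group on the same oxygen would test. Also open, on these data alone, is whether the same change on the core of compound 2 gives a step of similar size.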